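A few compounds are considered here, and "the series" means these few. Any claim that something is new, unique, unknown or untested is made for them only; others in the source may bear on it.

Measured so far in an assay on BHK21 (C13) cells (Mesocricetus auratus) for inhibition of thymidine kinase, cytosolic (Cricetulus griseus), using Lineweaver-Burk analysis; a higher number here means a weaker inhibitor, a lower number a stronger inhibitor:

compound 1 `CCCCCCNC[C@H]1O[C@@H](n2cc(C)c(=O)[nH]c2=O)C[C@@H]1O` gives 180000 nM
compound 2 `Cc1cn([C@H]2C[C@H](O)[C@@H](CSCCC(=O)O)O2)c(=O)[nH]c1=O` gives 500000 nM

Of the two numbers in this assay, compound 2 holds the higher one. Its nearest neighbour is compound 1, separated by a 2.8-fold higher number from compound 1 to compound 2 (0.44 log units; beyond the scatter), a change in which a (2-carboxyethyl)sulfanyl group replaces a hexylamino group on a saturated chain carbon bound to a saturated ring carbon.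

Compound 3 `Cc1cn([C@H]2C[C@H](O)[C@@H](CSCCCC(=O)O)O2)c(=O)[nH]c1=O` differs from compound 2 by carboxymethyl in place of carboxy on a saturated chain carbon, two bonds along the chain from a sulfur. Among the compounds with values here, no measured step touches this kind of change; the one step that exists, from compound 1 to compound 2, swaps one whole side chain for another rather than lengthening a chain by a single carbon. It therefore offers no direct guide. With nothing pointing one way or the other, compound 3 is expected to stay close to compound 2, and the estimated step of a 1.1-fold higher number from compound 2 to compound 3 (0.04 log units; within the scatter) is not expected to exceed the scatter. On that basis compound 3 is estimated at 550000 nM in this assay, within a range from 220000 nM to 1400000 nM.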

Compound 3, inhibition constant: 1200000 nM
Compound 3: middle estimate off by 2.2-fold (0.34 log units), on the low side, within the range that was stated.
By their numbers in this assay, from the lowest: compound 1; then compound 2; then compound 3.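

In this assay, the added carbon in the acid side chain is not a neutral change: carboxymethyl in place of carboxy, on a saturated chain carbon two bonds along the chain from a sulfur, gives a 2.4-fold higher number from compound 2 to compound 3 (0.38 log units; beyond the scatter) while the sulfur and the acid stay in the molecule. This is the first step shown that alters chain length alone, and exchanging the whole side chain now gives a 6.7-fold higher number from compound 1 to compound 3 (0.82 log units; beyond the scatter) so that (3-carboxypropyl)sulfanyl lies further from hexylamino than (2-carboxyethyl)sulfanyl does. Nothing available here accounts for this shift.

Within the data shown here, with only two acid chains compared, the single step cannot show whether a shorter chain such as (carboxymethyl)sulfanyl or a longer one such as (4-carboxybutyl)sulfanyl would continue the same direction. Going by these compounds, it also remains open whether replacing the carboxylic acid on the sulfur-linked chain with an amide, an ester or an amine would bring the number back toward that of compound 1.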